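Lengthening the phenoxy linker on a cinnamic acid scaffold

The source may report more compounds than this note shows. Statements on the series, on what has been measured and on what is new or still open speak of the compounds shown alone.

In an assay on CHO cells for displacement of a labelled ligand from prostaglandin E2 receptor EP1 subtype (Mus musculus), read by scintillation counting (a higher number here means a weaker inhibitor, a lower number a stronger inhibitor), compound 1 `O=C(O)/C=C/c1ccc(Cn2cccn2)cc1OCCc1ccc2ccccc2c1` gives 2900 nM. Compound 2 `Cc1ccc(/C=C/C(=O)O)c(OCCC2(C)CCc3c(C)c(O)c(C)c(C)c3O2)c1` reaches only a limit of this assay, > 10000 nM. Compound 3 `O=C(O)/C=C/c1ccc(Cn2ccnc2)cc1OCCCOc1ccccc1` likewise stops at a limit of this assay, > 10000 nM. Compound 3 therefore stands at the weak end of what has been shown, at the limit of > 10000 nM in this assay, at which 2 of the 3 values shown sit. Compound 4 `O=C(O)/C=C/c1ccc(Cn2ccnc2)cc1OCCCCOc1ccccc1` differs from compound 3 in one place: phenoxymethyl in place of phenoxy on a saturated chain carbon, three bonds along the chain from an oxygen on an aromatic ring. Within the data shown here, no two measured compounds differ in exactly one place, so no step of this kind has been measured. Lengthening the chain is expected to shift binding little, if at all, beyond the scatter, so the step of an at least 1.1-fold lower number from compound 3 to compound 4 (0.04 log units; that floor lies within the scatter) is expected to be small. Compound 4 is accordingly estimated at 9000 nM, within a range from 2500 nM to 30000 nM.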

Compound 4, inhibition constant: > 10000 nM
Compound 4 gave a limit, no number (the forecaster's own chance of this, stated with the estimate: 65%); middle value at least 1.1-fold (0.04 log units) away from the limit.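

Compound 3 and compound 4 both stop at a limit in this assay, so no step can be read between them: the limit of > 10000 nM in this assay, at which 3 of the 4 values shown sit.

From the compounds shown here alone, whether phenoxymethyl in place of phenoxy changes binding at all remains open.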